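Butanoyl ester of the hydroxy core: cytotoxicity before measurement

The compounds below may be only part of what the source reports. "The series", "measured", "known", "first", "only" and "open" are said of these compounds alone.

Measured so far:
compound 1 `CCCC(=O)O[C@]12C=CC(=O)C[C@H]1OCC2`, 2.7 ug/mL
compound 2 `CCCCCC(=O)O[C@]12C=CC(=O)C[C@H]1OCC2`, 1.8 ug/mL
compound 3 `CC(=O)O[C@]12C=CC(O)C[C@H]1OCC2`, > 100 ug/mL

The three measured compounds were tested in a functional assay on HeLa S3 cells (Homo sapiens) for cytotoxicity; a lower number here means a stronger inhibitor, a higher number a weaker inhibitor. Compound 1 `CCCC(=O)O[C@]12C=CC(=O)C[C@H]1OCC2` gives 2.7 ug/mL in this assay. Compound 2 `CCCCCC(=O)O[C@]12C=CC(=O)C[C@H]1OCC2` gives 1.8 ug/mL. The two differ by ethyl in place of hydrogen on a saturated chain carbon, three bonds along the chain from a carbonyl carbon, and the step of a 1.5-fold lower number from compound 1 to compound 2 (0.18 log units; within the scatter) is within the scatter, so the two values are read as equal.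

Compound 3 `CC(=O)O[C@]12C=CC(O)C[C@H]1OCC2` reaches only the limit > 100 ug/mL in this assay; this is a limit of the assay and not a number (the limit of > 100 ug/mL in this assay, at which 1 of the 3 values shown sits). The difference between the core of compound 3 and the core of compound 1 is not broken down here.

Compound 4 `CCCC(=O)O[C@]12C=CC(O)C[C@H]1OCC2` has not yet been measured. It differs from compound 3 by ethyl in place of hydrogen on a saturated chain carbon bound to a carbonyl carbon. Among the compounds with values here, this is the same kind of change as the one from compound 1 to compound 2, but the place is not the same: in compound 4 it sits on a saturated chain carbon bound to a carbonyl carbon, whereas in compound 2 it sits three bonds along the chain from a carbonyl carbon. Since the measured step of a 1.5-fold lower number from compound 1 to compound 2 (0.18 log units; within the scatter) lies within the scatter, the expected step of a number no higher from compound 3 to compound 4 (the limit leaves the size open) for compound 4 is likewise small. The value of compound 4 in this assay is therefore estimated at 100 ug/mL, with a range from 40 ug/mL to 300 ug/mL, and most likely again only a limit.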

Compound 4, half-maximal inhibitory concentration: 8.8 ug/mL
Compound 4: middle estimate off by 11-fold (1.06 log units), on the high side; measured number outside the range, below it.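

In this assay, acetyl to propylcarbonyl on the core of compound 3 gives an at least 11-fold lower number from compound 3 to compound 4 (1.05 log units; beyond the scatter), so ethyl in place of hydrogen does not carry a single effect from one core to the other in this series: the same change on two cores in this assay, a 1.5-fold lower number (0.18 log units; within the scatter) from compound 1 to compound 2 and an at least 11-fold lower number (1.05 log units; beyond the scatter) from compound 3 to compound 4, at least 7.5-fold (0.87 log units) apart, beyond the scatter of two such steps

From the compounds shown here alone, the figure for compound 3, > 100 ug/mL, is a limit of the assay and not a number, so the true size of this step remains unknown, although it is printed as large and beyond the scatter.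

The result does not show that the core alone sets the gap between the two steps, since the change also sits in a different place: on a saturated chain carbon bound to a carbonyl carbon in compound 4, and three bonds along the chain from a carbonyl carbon in compound 2.

The compounds shown leave open how the ester chain of compound 2 would behave on the core of compound 3, a comparison that would help to separate the effect of the core from that of the place. They also leave open whether a longer chain, an amine or a carboxylic acid in the ester would follow the same course on either core.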